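Replacing the remaining nitro group of compound 2

The source may report more compounds than this note shows. Statements on the series, on what has been measured and on what is new or still open speak of the compounds shown alone.

Measured in a functional assay on K562 cells (Homo sapiens) for cytotoxicity, read by trypan blue exclusion, with a stated time of 96 h; on this read-out higher numbers stand for weaker inhibition and lower numbers for stronger inhibition:
compound 1 `COc1cc(OC)c(/C=C/S(=O)(=O)Nc2cc([N+](=O)[O-])c(OC)c([N+](=O)[O-])c2)c(OC)c1`: 10000 nM
compound 2 `COc1cc(OC)c(/C=C/S(=O)(=O)Nc2ccc(OC)c([N+](=O)[O-])c2)c(OC)c1`: 1000 nM

Compound 2 holds the lower of the two numbers in this assay, at 1000 nM. Compound 3 `COC(=O)C(Nc1cc(NS(=O)(=O)/C=C/c2c(OC)cc(OC)cc2OC)ccc1OC)c1ccccc1` differs from it as follows: a group of 12 heavy atoms (9 carbon, 1 nitrogen, 2 oxygen; one six-membered aromatic ring of carbon only) in place of a group of 3 heavy atoms (1 nitrogen, 2 oxygen; no ring), on an aromatic carbon. Going by the values given here, the only measured step is a 10-fold lower number from compound 1 to compound 2 (1.00 log units; beyond the scatter), where hydrogen took the place of a nitro group. Among the compounds with values here, that step also removes a nitro group but brings in no new group, so it bears only loosely, and no measured compound carries the larger group. A modest further move towards a lower number is therefore expected, with wide uncertainty. The expected step is a 3.3-fold lower number from compound 2 to compound 3 (0.52 log units; beyond the scatter). For compound 3 the estimated value is 300 nM, with an expected range of 30 nM to 3000 nM.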

Compound 3, half-maximal inhibitory concentration: 2500 nM
Compound 3: the middle estimate sits 8.3-fold (0.92 log units) below what was measured, and the stated range covers the measured number.
By their numbers in this assay, from the lowest: compound 2; then compound 3; then compound 1.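

In this assay, exchanging the nitro group for the much larger group with its six-membered aromatic ring gives a 2.5-fold higher number from compound 2 to compound 3 (0.40 log units; beyond the scatter). This position, ortho to a methoxy group, therefore accepts a group of 12 heavy atoms at only a modest cost, something the earlier removal of a nitro group could not show. Nothing available explains the direction of this step. Still open, from the compounds shown here alone, is how a primary amine would read at this position, and whether a carboxylic acid in place of the ester within the large group would change the number.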